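From compound 3 to compound 4: a step among limits

A few compounds are considered here, and "the series" means these few. Any claim that something is new, unique, unknown or untested is made for them only; others in the source may bear on it.

Measured in an ADME assay on HEK293 cells (Homo sapiens) for cytotoxicity, read by resazurin assay, with a stated time of 72 h; a higher number here means that more compound is tolerated, a lower number that less compound is tolerated:
Compound 1 `O=C(O)c1ccc(CCOc2c(F)ccc3nc(C(=O)NCc4ccccc4)[nH]c(=O)c23)cc1`: > 20000 nM
Compound 2 `O=C(O)c1ccc(CCOc2c(F)ccc3nc(C(=O)NCC4CCCCC4)[nH]c(=O)c23)cc1`: > 20000 nM
Compound 3 `Cc1cc(CNC(=O)c2nc3ccc(F)c(OCCc4ccc(C(=O)O)cc4)c3c(=O)[nH]2)ccc1F`: > 20000 nM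

All three results are limits, not numbers, and the series sits at the limit of > 20000 nM in this assay, at which 3 of the 3 values shown sit. In this assay compound 3 gives > 20000 nM, which is a limit. Compound 4 `O=C(O)c1ccc(CCOc2c(F)ccc3nc(C(=O)NCc4cccc(OCC5CC5)c4)[nH]c(=O)c23)cc1` carries 3-(cyclopropylmethoxy)phenyl in place of 4-fluoro-3-methylphenyl on a saturated chain carbon bound to an amide-type nitrogen. Three measured changes fall at this same place: a step that the two limits leave unreadable from compound 1 to compound 2, a step that the two limits leave unreadable from compound 1 to compound 3 and a step that the two limits leave unreadable from compound 2 to compound 3. None has a readable size, so they set no size for this change. No step beyond the scatter is expected, and the expected step is a step that the limit leaves unreadable from compound 3 to compound 4. Compound 4 is estimated at 25000 nM, with an expected range of 10000 nM to 50000 nM.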

Compound 4, half-maximal cytotoxic concentration: > 20000 nM
Compound 4: only a limit was reported; the forecaster's own chance of this, stated with the estimate: 80%; the middle value is on the limit's open side.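

In this assay compound 4 gives > 20000 nM, again a limit, so its steps from compound 1, compound 2 and compound 3 cannot be read: the limit of > 20000 nM in this assay, at which 4 of the 4 values shown sit.

The compounds shown leave open whether any change at this place shifts the result in this assay.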